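Moving to 2,4,5-trifluorophenyl on the shared core

The source may hold more compounds than are shown below. What is called first, only, known or untested is meant among the compounds shown, and "the series" means these compounds.

Measured in a functional assay on HFF cells (Homo sapiens) for cytotoxicity (a lower number here means a stronger inhibitor, a higher number a weaker inhibitor), both values being limits:
- compound 1 `Cc1ccc(/C=C2\SC(=S)N(NS(=O)(=O)c3ccccc3)C2=O)cc1` gives > 100000 nM
- compound 2 `O=C1/C(=C/c2ccc(F)c(F)c2F)SC(=S)N1NS(=O)(=O)c1ccccc1` gives > 100000 nM

Compound 2 stands only at a limit (> 100000 nM). For the measured compounds named here, the series so far offers nothing else, with every value at one limit (the limit of > 100000 nM in this assay, at which 2 of the 2 values shown sit).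

Compound 3 `O=C1/C(=C/c2cc(F)c(F)cc2F)SC(=S)N1NS(=O)(=O)c1ccccc1` has 2,4,5-trifluorophenyl in place of 2,3,4-trifluorophenyl on a double-bonded chain carbon bound to a double-bonded ring carbon.

Going by the values given here, one measured step bears on this change, a step that the two limits leave unreadable from compound 1 to compound 2, and its size cannot be read. No step beyond the scatter is therefore expected in this assay, and no direction can be given. The expected change is a number no higher from compound 2 to compound 3 (the limit leaves the size open). Compound 3 is estimated at 100000 nM, with an expected range from 40000 nM to 200000 nM.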

Compound 3, half-maximal inhibitory concentration: > 100000 nM
Compound 3: no number, only a limit; the forecaster's own chance of this, stated with the estimate: 85%; the middle value sits exactly at the limit.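

No new step can be read from compound 3 to compound 1 or compound 2, since all three values are limits: the limit of > 100000 nM in this assay, at which 3 of the 3 values shown sit.

The compounds shown leave open how the 4-methylphenyl, 2,3,4-trifluorophenyl and 2,4,5-trifluorophenyl groups on the shared core rank in this assay.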